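The source may report more compounds than this note shows. Statements on the series, on what has been measured and on what is new or still open speak of the compounds shown alone.

Measured compounds:

Compound 1 `CC[C@H](C)[C@H]1C(=O)N[C@H](Cc2cc(Cl)c(O)c(Cl)c2)C(=O)N[C@@H](C(C)C)C(=O)O[C@H](c2ccccc2)[C@H](C)/C=C/C=C(\C)[C@H](OC)C[C@@H]2O[C@@]2(C)C(=O)N1C` gives 4.25 nM in a functional assay on HCT-116 cells (Homo sapiens) for antiproliferative activity; on this read-out higher numbers stand for weaker inhibition and lower numbers for stronger inhibition.
Compound 2 `CC[C@H](C)[C@H]1C(=O)N[C@H](Cc2cc(Cl)c(O)c(Cl)c2)C(=O)N[C@@H](C(C)C)C(=O)O[C@H](c2ccccc2)[C@H](C)/C=C/C=C(\C)[C@H](OC)C/C=C(\C)C(=O)N1C` gives 21.6 nM in this assay.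
Compound 3 `CC[C@H](C)[C@H]1C(=O)N[C@H](Cc2ccc(O)c(Br)c2)C(=O)N[C@@H](C(C)C)C(=O)O[C@H](c2ccccc2)[C@H](C)/C=C/C=C(\C)[C@H](OC)C[C@@H]2O[C@@]2(C)C(=O)N1C` gives 3.93 nM in this assay.

Compounds 1 and 3 share one core, and compound 2 carries a second core; how the two cores differ is not broken down here. Of the three measured numbers, compound 2 has the highest, and its distance from compound 1 and from compound 3 lies beyond the scatter in each case.

Between compound 1 and compound 3 the only change is 3-bromo-4-hydroxyphenyl in place of 3,5-dichloro-4-hydroxyphenyl on a saturated chain carbon bound to a saturated ring carbon. The step this made was a 1.1-fold lower number from compound 1 to compound 3 (0.03 log units; within the scatter), so on this read-out the two compounds are not told apart.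

Compound 4 `CC[C@H](C)[C@H]1C(=O)N[C@H](Cc2ccc(O)c(Br)c2)C(=O)N[C@@H](C(C)C)C(=O)O[C@H](c2ccccc2)[C@H](C)/C=C/C=C(\C)[C@H](OC)C/C=C(\C)C(=O)N1C` is not yet measured. Among the measured compounds shown here, it differs from compound 2 by 3-bromo-4-hydroxyphenyl in place of 3,5-dichloro-4-hydroxyphenyl on a saturated chain carbon bound to a saturated ring carbon, which is the same change, at the same place, as the one made from compound 1 to compound 3. The expectation for compound 4 therefore rests on the earlier step: because that step was a 1.1-fold lower number from compound 1 to compound 3 (0.03 log units; within the scatter), the step from compound 2 to compound 4 is expected to be a 1.1-fold lower number from compound 2 to compound 4 (0.03 log units; within the scatter). Compound 4 is thus estimated at 20 nM, with a likely range from 10 nM to 40 nM.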

Compound 4, half-maximal inhibitory concentration: 13.2 nM
Compound 4: middle estimate off by 1.5-fold (0.18 log units), on the high side; measured number inside the range.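

In this assay, putting 3-bromo-4-hydroxyphenyl in place of 3,5-dichloro-4-hydroxyphenyl on the second core gave a 1.6-fold lower number from compound 2 to compound 4 (0.21 log units; within the scatter), so this assay does not tell the two compounds apart. Set beside the same change on the first core, the two steps do not differ: the same change on two cores in this assay, a 1.1-fold lower number (0.03 log units; within the scatter) from compound 1 to compound 3 and a 1.6-fold lower number (0.21 log units; within the scatter) from compound 2 to compound 4, 1.5-fold (0.18 log units) apart, within the scatter of two such steps This shows that, for these two pairs, the swap of halogenated phenyl groups had no effect that could be read on either core, but it does not show that any change carries from one core to the other, since a step that stays within the scatter is a weak test of that, and two pairs make no general rule.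

The compounds shown leave open whether a change with a larger step would also carry across these cores. They also leave open how either core would respond if the halogens gave way to an amine or a carboxylic acid on the phenyl ring.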